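Adding a 4-methoxyphenyl Group Across Two Related Cores

The compounds below may be only part of what the source reports. "The series", "measured", "known", "first", "only" and "open" are said of these compounds alone.

Compound 1 `COc1ccc(Cn2cc3cc(C(=N)Nc4ccc(N5CCN(C)CC5)cc4)ncc3n2)cc1`: 8000 nM
Compound 2 `CN1CCN(c2ccc(NC(=N)c3cc4cn(C)nc4cn3)cc2)CC1`: 20500 nM
Compound 3 `CN1CCN(c2ccc(NC(=N)c3cc4cnn(C)c4cn3)cc2)CC1`: 30200 nM

All three measured compounds were tested in a functional assay on MDA-MB-231 cells (Homo sapiens) for cytotoxicity, read by MTT assay, with a stated time of 72 h; on this read-out higher numbers stand for weaker inhibition and lower numbers for stronger inhibition. Compound 2 and compound 3 are built from the same atoms joined differently; the difference between their two cores is not broken down here, and their values lie within the scatter of each other. Compound 1 differs from compound 2 by 4-methoxyphenyl in place of hydrogen on a saturated chain carbon bound to an aromatic nitrogen, and this change gave a 2.6-fold lower number from compound 2 to compound 1 (0.41 log units; beyond the scatter). Compound 4 `COc1ccc(Cn2ncc3cc(C(=N)Nc4ccc(N5CCN(C)CC5)cc4)ncc32)cc1` carries the same change on the core of compound 3: 4-methoxyphenyl in place of hydrogen on a saturated chain carbon bound to an aromatic nitrogen. Because the same change once produced a 2.6-fold lower number from compound 2 to compound 1 (0.41 log units; beyond the scatter), a step of similar size is expected here, a 2.6-fold lower number from compound 3 to compound 4 (0.42 log units; beyond the scatter), though it rests on a single measured pair. Compound 4 is therefore estimated at 11600 nM, with a likely range from 5000 nM to 27000 nM.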

Compound 4, half-maximal inhibitory concentration: 5700 nM
Beside the measured number, compound 4's estimate is 2.0-fold (0.31 log units) above it; measured number inside the range.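

On the second core, the change from methyl to 4-methoxybenzyl gave a 5.3-fold lower number from compound 3 to compound 4 (0.72 log units; beyond the scatter) in this assay. The change therefore lowered the number on both cores, and the two steps do not differ in size by more than the scatter allows: the same change on two cores in this assay, a 2.6-fold lower number (0.41 log units; beyond the scatter) from compound 2 to compound 1 and a 5.3-fold lower number (0.72 log units; beyond the scatter) from compound 3 to compound 4, 2.1-fold (0.32 log units) apart, within the scatter of two such steps. Among the compounds shown here, this rests on only two pairs, so it shows that the change carried over between these two cores but not that it would carry to any other core, and it does not explain the lower numbers.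

The compounds shown leave open what a plain benzyl or a 4-hydroxybenzyl group would give in that place. They also leave open how a longer chain, such as propyl, would compare.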